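The source may report more compounds than this note shows. Statements on the series, on what has been measured and on what is new or still open speak of the compounds shown alone.

Measured in an assay on isolated protein for inhibition of DNA topoisomerase 1 (Homo sapiens), with a stated time of 30 min, tested at 20 uM; a higher number here means a stronger effect of the compound at the concentration tested, a lower number a weaker effect:
Compound 1, `Cc1ccc2c(=O)[nH]c(-c3cccc(OC(F)(F)F)c3)nc2c1`: 0%
Compound 2, `CCN(CC)c1ccc2nc(-c3cccc4ccccc34)[nH]c(=O)c2c1`: 25.5%
Compound 3, `COc1cccc(-c2nc3cc(C)ccc3c(=O)[nH]2)c1`: 80%

Compound 3 stands highest of the three in this assay; compound 2 lies nearest to it and compound 1 furthest, both beyond the scatter. Compound 4, `Cc1ccc2c(=O)[nH]c(-c3cccc(F)c3)nc2c1`, has not yet been measured. It differs from compound 3 in one place: fluoro in place of methoxy on an aromatic carbon. Among the measured compounds shown here, only one measured step touches this part of the molecule: a number 80 percentage points higher from compound 1 to compound 3 (beyond the scatter). For the measured compounds named here, that step exchanged methyl for trifluoromethyl on an oxygen; the present change removes the methoxy altogether, and no measured pair shows a fluoro at this carbon. Given the large swing already seen here, a downward step beyond the scatter in this assay is expected, though its size is uncertain. Compound 4 is therefore expected to give 35%, within 5% to 70%, which would mean a number 45 percentage points lower from compound 3 to compound 4 (beyond the scatter).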

Compound 4, a percentage reported as inhibition, at one concentration (the size of the read-out at that concentration, not a potency): 4.3%
Compound 4: the middle estimate sits 30.7 percentage points above what was measured; measured number below the stated range.
By their numbers in this assay, from the lowest: compounds 1 and 4 (each within the scatter of the next); then compound 2; then compound 3.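

Fluoro in place of methoxy on this aromatic carbon gives a number 75.7 percentage points lower from compound 3 to compound 4 (beyond the scatter) in this assay, so the high read-out does not survive removal of the methoxy. Fluoro and trifluoromethoxy cannot be told apart here, with a number 4.3 percentage points higher from compound 1 to compound 4 (within the scatter), and among these three groups on the shared core only methoxy goes with a high read-out. No evidence is available on what underlies this difference.

As far as these compounds go, it remains open whether the read-out follows the oxygen or the methyl on it. A hydroxyl, an ethoxy or an amine on this carbon would help to separate the two.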